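Swapping Cyclopropyl for 4-Fluorophenyl on the Amide Nitrogen

The source may hold more compounds than are shown below. What is called first, only, known or untested is meant among the compounds shown, and "the series" means these compounds.

Compound 1 `O=C1COc2ccc(-c3cccc(NS(=O)(=O)c4ccc(F)cc4)c3)cc2N1C1CC1` is the starting point of this step. In a functional assay on HepG2 cells (Homo sapiens) for antiproliferative activity, read by MTT assay, with a stated time of 72 h (on this read-out lower numbers stand for stronger inhibition and higher numbers for weaker inhibition), compound 1 gives > 40000 nM, which is a limit of the assay and not a measured number. Compound 1 thus stands at the limit of > 40000 nM in this assay, at which 2 of the 3 values shown sit. Compound 2 `COc1ccc(N2C(=O)COc3ccc(-c4cnc5ccccc5c4)cc32)cc1` gives > 40000 nM in this assay, again a limit rather than a number. For the measured compounds named here, compound 3 `CC(C)N1C(=O)COc2ccc(-c3cnc(Cl)c(NS(=O)(=O)c4ccc(F)cc4)c3)cc21` is the only one with a plain value, giving 21500 nM in this assay. These three share the same fused bicyclic core but differ in several places at once, so no single change can be followed between them.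

Compound 4 `O=C1COc2ccc(-c3cccc(NS(=O)(=O)c4ccc(F)cc4)c3)cc2N1c1ccc(F)cc1` has not yet been measured. It differs from compound 1 in one place only: 4-fluorophenyl in place of cyclopropyl on an amide-type nitrogen in a ring. Going by the values given here, no measured pair isolates this change, so no step beyond the usual scatter is expected in this assay, and compound 4 may well land at the same limit. The estimate for compound 4 is 35000 nM, within a range from 8000 nM to 120000 nM. That estimate implies an expected step of an at least 1.1-fold lower number from compound 1 to compound 4 (0.05 log units; that floor lies within the scatter).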

Compound 4, half-maximal inhibitory concentration: > 40000 nM
Compound 4: only a limit was reported; the forecaster's own chance of this, stated with the estimate: 55%; middle value at least 1.1-fold (0.05 log units) from the limit.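

Compound 1 and compound 4 each give only a limit in this assay, not a number, so no step can be read between them: the limit of > 40000 nM in this assay, at which 3 of the 4 values shown sit.

The compounds shown leave open whether 4-fluorophenyl in place of cyclopropyl on the amide-type nitrogen changes the activity at all.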